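This account rests on a few compounds, and the source may have more. Where it says the series, first, only, none or still open, it means among the compounds named here.

In an ADME assay on microsomes from liver (Rattus norvegicus) for metabolic stability (a lower number here means slower removal, a higher number faster removal of the compound), compound 1 `O=C(O)CCNC(=O)c1ccc(C(Oc2ccc(-n3cc(C(F)(F)F)cn3)cc2)C2CCC2)cc1` gives < 25 mL/min/kg, which is a limit of the assay and not a number. Among the measured compounds shown here, compound 2 `O=C(O)CCNC(=O)c1ccc(C(Oc2ccc(-n3cc(C(F)(F)F)cn3)cc2)C2CCCC2)cc1` gives 31 mL/min/kg, the only actual number so far. Compound 3 `CC(C)(C)C(Oc1ccc(-n2cc(C(F)(F)F)cn2)cc1)c1ccc(C(=O)NCCC(=O)O)cc1` has not been measured and differs from compound 2 in one place: tert-butyl in place of cyclopentyl on a saturated chain carbon bound to an aromatic carbon and an oxygen on an aromatic ring. For the measured compounds named here, only one measured step bears on this change, cyclopentyl in place of cyclobutyl on the same saturated chain carbon, and it reads an at least 1.2-fold higher number from compound 1 to compound 2 (0.09 log units; that floor lies within the scatter). On these data alone, since that step rests on a limit, its true size remains unknown, and it offers only a weak guide. No clear shift in clearance is expected in this assay, so the expected step, a 1.2-fold lower number from compound 2 to compound 3 (0.08 log units; within the scatter), is small, slightly downward and within the scatter. Compound 3 is estimated at 26 mL/min/kg, with an expected range from 14 mL/min/kg to 50 mL/min/kg.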

Compound 3, clearance in the Rattus norvegicus assay: 28 mL/min/kg
For compound 3 the middle estimate is 1.1-fold (0.03 log units) below the measured one; low and high end bracket the measured number.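

In the Rattus norvegicus assay, tert-butyl in place of cyclopentyl on this saturated chain carbon gives no real shift, a 1.1-fold lower number from compound 2 to compound 3 (0.04 log units; within the scatter), so an open-chain group here reads the same as the ring. On these data alone, compound 1 stands at a limit of the assay, which leaves, in the Rattus norvegicus assay, an at least 1.1-fold higher number from compound 1 to compound 3 (0.04 log units; that floor lies within the scatter) as a floor only, and the true size of that step stays unknown. In a physicochemical assay for lipophilicity, using the shake flask method, at pH 7.4 (on this read-out higher numbers stand for higher lipophilicity and lower numbers for lower lipophilicity), compound 2 gives 3.3 and compound 3 gives 3.7. The same change does separate the two compounds in the physicochemical assay, yet the clearance numbers did not follow that rise: the measured distribution coefficient of compound 2, 3.3, and of compound 3, 3.7, a number 0.40 log units higher (beyond the scatter)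

The compounds shown leave open whether a much smaller group such as methyl, or a group carrying an amine or an ether oxygen, would behave the same way on this carbon. They also do not tell how any such group would change clearance when the distribution coefficient falls rather than rises.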